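The compounds below may be only part of what the source reports. "The series", "measured", "known", "first", "only" and "open" are said of these compounds alone.

Series so far, all in a functional assay on MCF7 cells (Homo sapiens) for inhibition, read by MTT assay, with a stated time of 3 days; on this read-out lower numbers stand for stronger inhibition and higher numbers for weaker inhibition
- compound 1 `COc1ccccc1/C=C/CCCOc1cc(/C=C\c2cc(OC)c(OC)c(OC)c2)ccc1OC` gives 21000 nM
- compound 2 `COc1cccc(/C=C/CCCOc2cc(/C=C\c3cc(OC)c(OC)c(OC)c3)ccc2OC)c1` gives 41000 nM
- compound 3 `COc1ccc(/C=C\c2cc(OC)c(OC)c(OC)c2)cc1OCCC/C=C/c1ccc(F)cc1` gives 16000 nM

The three differ only in the phenyl group at the end of the chain. Compound 3 lies within the scatter of one neighbour (a 1.3-fold lower number from compound 1 to compound 3 (0.12 log units; within the scatter)) and clear of the other (a 2.6-fold lower number from compound 2 to compound 3 (0.41 log units; beyond the scatter)), the latter a modest step. The remaining exchange is a 2.0-fold higher number from compound 1 to compound 2 (0.29 log units; within the scatter) and stays within the scatter.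

Next is compound 4 `COc1ccc(/C=C\c2cc(OC)c(OC)c(OC)c2)cc1OCCC/C=C/c1ccc(Cl)cc1` with the change chloro in place of fluoro on an aromatic carbon (chloro in place of fluoro on an aromatic carbon, para to a large group). Within the data shown here, no measured compound carries chloro, so no step measures this exchange directly. Among the measured compounds shown here, the only guide is the three exchanges above, in which 2-methoxyphenyl, 3-methoxyphenyl and 4-fluorophenyl replace one another. The largest of them is a 2.6-fold lower number from compound 2 to compound 3 (0.41 log units; beyond the scatter) and it swaps a whole substituent, whereas here 4-fluorophenyl becomes 4-chlorophenyl. No shift beyond the scatter is therefore expected, and the anchor is compound 3 at 16000 nM in this assay as the closest measured structure.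

The expected step is a 1.1-fold higher number from compound 3 to compound 4 (0.03 log units; within the scatter) in this assay as estimated here.

For compound 4 the estimated value is 17000 nM with an expected range from 8000 nM to 36000 nM in this series.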

Compound 4, half-maximal inhibitory concentration: 40000 nM
Estimate against measurement, compound 4: 2.4-fold (0.37 log units) below, and the stated range ends below it.
By their numbers in this assay, from the lowest: compounds 3, 1, 4 and 2 (each within the scatter of the next, the first and the last beyond it).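

In this assay, among these compounds, the exchange of fluoro for chloro on an aromatic carbon, para to a large group, is the first change of a single atom at this end of the chain, and it registers: a 2.5-fold higher number from compound 3 to compound 4 (0.40 log units; beyond the scatter). That modest step shows that a small exchange can move the number as far as the largest exchange of a whole substituent seen earlier, so 4-fluorophenyl and 4-chlorophenyl cannot be treated as interchangeable here, while 4-chlorophenyl shows no separation from either methoxyphenyl group: a 1.0-fold lower number from compound 2 to compound 4 (0.01 log units; within the scatter), and a 1.9-fold higher number from compound 1 to compound 4 (0.28 log units; within the scatter). Nothing at hand accounts for the gap between fluoro and chloro.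

The compounds shown leave open how an unsubstituted phenyl, a 4-bromophenyl or a 4-methoxyphenyl group would read at this chain end, and so whether compound 3 is an isolated case or part of a trend among the halogens. They also leave open whether a longer chain, or an amine in place of the end phenyl group, would carry the number beyond the span of these four compounds.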